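A few compounds are considered here, and "the series" means these few. Any claim that something is new, unique, unknown or untested is made for them only; others in the source may bear on it.

In an ADME assay on BJ cells (Homo sapiens) for inhibition, read by fluorescence and resazurin assay, with a stated time of 72 h (a lower number here means a stronger inhibitor of growth, a higher number a weaker inhibitor of growth), compound 1 (`Nc1ccccc1-c1ccc(Nc2nc(N[C@H]3CC[C@H](N)CC3)nc3c2ncn3C2CCCC2)cc1`) gives 12500 nM, compound 2 (`N[C@H]1CC[C@H](Nc2nc(Nc3ccc(-c4ccoc4)nc3)c3ncn(C4CCCC4)c3n2)CC1`) gives 13100 nM and compound 3 (`COc1ccc(-c2ccc(Nc3nc(N[C@H]4CC[C@H](N)CC4)nc4c3ncn4C3CCCC3)cn2)cc1`) gives 7230 nM, so compound 1 stands within the scatter of both others. Compound 4 (`N[C@H]1CC[C@H](Nc2nc(Nc3ccc(Oc4nccs4)cc3)c3ncn(C4CCCC4)c3n2)CC1`) differs from compound 1 by (1,3-thiazol-2-yl)oxy in place of 2-aminophenyl on an aromatic carbon. For the measured compounds named here, the one measured step that exchanges one aromatic group for another is a 1.8-fold lower number from compound 2 to compound 3 (0.26 log units; within the scatter). Going by the values given here, no measured compound carries the (1,3-thiazol-2-yl)oxy group, so this step offers only indirect guidance. No change beyond the scatter is therefore expected in this assay, in either direction. The estimate means a 1.3-fold lower number from compound 1 to compound 4 (0.10 log units; within the scatter). For compound 4 the expected value is 10000 nM, with an estimated range of 4500 nM to 22000 nM.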

Compound 4, concentration for 50% growth inhibition: 6850 nM
Compound 4: the middle estimate sits 1.5-fold (0.16 log units) above what was measured; low and high end bracket the measured number.
By their numbers in this assay, from the lowest: compounds 4, 3, 1 and 2 (each within the scatter of the next).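

At the aromatic carbon para to a large group, (1,3-thiazol-2-yl)oxy replaces 2-aminophenyl with a 1.8-fold lower number from compound 1 to compound 4 (0.26 log units; within the scatter) in this assay and leaves the number within the scatter. This position therefore accepts a five-membered aromatic ring with 2 hetero atoms, with 0 hydrogen-bond donors, in place of a six-membered aromatic ring of carbon only, without a change beyond the scatter. No measurement available here offers an explanation for this step. On these data alone, whether any group at this position moves the number beyond the scatter remains open. A carboxylic acid or a simple amine on the same aromatic carbon would test this.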